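Replacing the pyridinylmethylamine arm of compound 2

This account rests on a few compounds, and the source may have more. Where it says the series, first, only, none or still open, it means among the compounds named here.

Measured compounds:
compound 1, `c1cncc(CN(CCCCN(C[C@H]2Cc3ccccc3CN2)[C@H]2CCCc3cccnc32)Cc2cccnc2)c1`, 471 nM
compound 2, `c1ccc2c(c1)CN[C@@H](CN(CCCCNCc1ccncc1)[C@H]1CCCc3cccnc31)C2`, 22.7 nM

Of the compounds shown here, two have been measured in a functional assay on cells for antagonist activity at C-X-C chemokine receptor type 4 (Homo sapiens), read by fluorescence and calcium flux, with stated times of 25 min and 90 s; on this read-out higher numbers stand for weaker inhibition and lower numbers for stronger inhibition. Compound 1 gives 471 nM, and compound 2 gives 22.7 nM, the lowest number of the two; the gap between them is beyond the usual scatter. Compound 3, `C(=C/CN(C[C@H]1Cc2ccccc2CN1)[C@H]1CCCc2cccnc21)\CNC1CCOCC1`, has not yet been measured. Compared with compound 2 it carries the change (3-((oxan-4-yl)amino)prop-1-en-1-yl in place of 3-(((pyridin-4-yl)methyl)amino)propyl on a saturated chain carbon bound to an amine nitrogen). Going by the values given here, no step between two measured compounds separates this change from others, so the expectation rests on compound 2 alone. Since compound 2 stands at 22.7 nM and the change keeps one hydrogen-bond donor and two acceptors, a moderate step in this assay toward a higher number is expected, a 2.6-fold higher number from compound 2 to compound 3 (0.42 log units; beyond the scatter), though it could lie within the scatter. Compound 3 is thus estimated at 60 nM, with a range of 15 nM to 250 nM.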

Compound 3, half-maximal inhibitory concentration: 15.5 nM
Estimate against measurement, compound 3: 3.9-fold (0.59 log units) above, and the stated range covers the measured number.
By their numbers in this assay, from the lowest: compounds 3 and 2 (each within the scatter of the next); then compound 1.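

In this assay, putting 3-((oxan-4-yl)amino)prop-1-en-1-yl in place of 3-(((pyridin-4-yl)methyl)amino)propyl gives a 1.5-fold lower number from compound 2 to compound 3 (0.17 log units; within the scatter). At this place, on a saturated chain carbon bound to an amine nitrogen, the read-out therefore holds when the six-membered aromatic ring gives way to a six-membered non-aromatic ring and a double bond enters the chain. Nothing at hand explains why these two arms read alike.

The ring exchange and the double bond arrive together, and the compounds shown leave open what each does alone. A 3-((oxan-4-yl)amino)propyl arm would separate the two, and a piperidin-4-yl amine in place of the oxane would test whether the ring oxygen can be exchanged at this place.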